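A few compounds are considered here, and "the series" means these few. Any claim that something is new, unique, unknown or untested is made for them only; others in the source may bear on it.

Measured in a functional assay on HT-29 cells (Homo sapiens) for inhibition, read by CCK-8 assay, with a stated time of 24 h; a lower number here means a stronger inhibitor, a higher number a weaker inhibitor:
- Compound 1 `Cc1cccc(-n2cc(-c3ccc(/C=C4\C(=O)Nc5ccccc54)cc3)nn2)c1`: 3940 nM
- Compound 2 `O=C1Nc2ccccc2/C1=C/c1ccc(-c2cn(-c3cccc(F)c3)nn2)cc1`: > 20000 nM (a limit)
- Compound 3 `O=C1Nc2ccccc2/C1=C/c1ccc(-c2cn(-c3ccccc3Cl)nn2)cc1`: > 20000 nM (a limit)

Compound 3 stands at a limit, not a number: > 20000 nM. Compound 4 `O=C1Nc2ccccc2/C1=C/c1ccc(-c2cn(-c3cccc(Cl)c3)nn2)cc1` has the same atoms, joined differently: 3-chlorophenyl in place of 2-chlorophenyl on an aromatic nitrogen. In words, 3-chlorophenyl sits in place of 2-chlorophenyl on an aromatic nitrogen.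

Going by the values given here, two measured steps bear on this change: an at least 5.0-fold higher number from compound 1 to compound 2 (0.70 log units; beyond the scatter), and an at least 5.0-fold higher number from compound 1 to compound 3 (0.70 log units; beyond the scatter). Both lie beyond the scatter, but their full size is open. The remaining comparison is a step that the two limits leave unreadable from compound 2 to compound 3, so it offers no guide.

The closest neighbours of compound 4 disagree. Compound 1, with its 3-methylphenyl group, gives 3940 nM, which leaves room for a measurable value. Compound 2, with its 3-fluorophenyl group, remains at a limit, > 20000 nM, and so goes against that hope.

A modest move towards a lower number is therefore expected, which would be an at least 2.0-fold lower number from compound 3 to compound 4 (0.30 log units; that floor lies within the scatter). For compound 4 the estimate is 10000 nM, with an expected range of 3000 nM to 25000 nM.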

Compound 4, half-maximal inhibitory concentration: > 20000 nM
Compound 4: no number, only a limit; the forecaster's own chance of this, stated with the estimate: 40%; at least 2.0-fold (0.30 log units) between middle value and limit.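

In this assay, 3-chlorophenyl in place of 2-chlorophenyl on the aromatic nitrogen brings no measurable value: compound 4 stays at a limit, as compound 3 does. Chloro in place of methyl gives an at least 5.0-fold higher number from compound 1 to compound 4 (0.70 log units; beyond the scatter), which leaves compound 1 as the only compound shown with a number. The steps among compound 2, compound 3 and compound 4 cannot be read because each one joins two limits: the limit of > 20000 nM in this assay, at which 3 of the 4 values shown sit.

On these data alone, how far past that limit these three compounds lie remains unknown, so any order among them stays open. As far as these compounds go, it is also open whether an ethyl group or an amine in place of the methyl of compound 1 would keep a measurable value or give a lower number.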